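The source may hold more compounds than are shown below. What is called first, only, known or untested is meant among the compounds shown, and "the series" means these compounds.

Among the compounds with values here, compound 1, `CC(=O)N1N=C(Nc2nc3ccccc3s2)CC1OC1=CC=C1`, is one of two compounds measured in a functional assay on the whole organism (Hindlimb, strain albino) with Mus musculus as the target, in the maximal electroshock model, with a stated time of 0.5 h; a lower number here means that less compound is needed, a higher number that more compound is needed for the effect. In this assay, within the data shown here, compound 1 gives 382 umol/kg, the higher of the two numbers; the only neighbour is compound 2, `CC(=O)N1N=C(Nc2nc3ccc(Cl)cc3s2)CC1OC1=CC=C1`, which gives 212 umol/kg, so that a 1.8-fold lower number from compound 1 to compound 2 (0.26 log units; within the scatter), a change that lies within the usual scatter. Compound 3, `COc1ccc(C2CC(Nc3nc4ccccc4s3)=NN2C(C)=O)cc1`, differs from compound 1 at another place: a group of 8 heavy atoms (7 carbon, 1 oxygen; one six-membered aromatic ring of carbon only) in place of a group of 5 heavy atoms (4 carbon, 1 oxygen; one four-membered non-aromatic ring of carbon only), on a saturated ring carbon. Among the measured compounds shown here, the single measured step, chloro in place of hydrogen on an aromatic carbon, concerns a different part of the shared core and was itself within the scatter, so no measured step bears directly on the exchange at the saturated ring carbon. Compound 3 is therefore expected to stay close to compound 1, with an estimated step of a 1.0-fold lower number from compound 1 to compound 3 (0.00 log units; within the scatter). The estimate for compound 3 is 380 umol/kg, with a range from 140 umol/kg to 1000 umol/kg.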

Compound 3, dose for half-maximal effect: 226 umol/kg
The estimate for compound 3 lay 1.7-fold (0.23 log units) above the measured number, within the range that was stated.
By their numbers in this assay, from the lowest: compounds 2, 3 and 1 (each within the scatter of the next).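

Within the data shown here, the step at the saturated ring carbon in this assay, a 1.7-fold lower number from compound 1 to compound 3 (0.23 log units; within the scatter), is the first measured information about this position; the earlier pair spoke only of chloro on an aromatic carbon. It shows that 4-methoxyphenyl, a six-membered aromatic ring with more heavy atoms, can stand where the four-membered non-aromatic ring group stands in compound 1 and leave the number within the scatter, so this exchange of ring type and size gives no readable difference in this assay. Nothing available offers a reason for this result.

Going by these compounds, with only these two groups at this position, it remains open whether a primary amine, a carboxylic acid or a longer alkyl chain would also stay within the scatter there. Also open, on these data alone, is how chloro on the shared core would behave alongside 4-methoxyphenyl.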